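A Halogen Swap Carried Onto an Oxime Analogue

This account rests on a few compounds, and the source may have more. Where it says the series, first, only, none or still open, it means among the compounds named here.

The shared core carries a sulfur-linked side chain that ends in a substituted phenyl ring, and the question here is what happens when one halogen on that ring is exchanged for another. In a functional assay on MCF7 cells (Homo sapiens) for inhibition, read by MTT assay, with a stated time of 48 h (on this read-out higher numbers stand for weaker inhibition and lower numbers for stronger inhibition), compound 1 `Cn1c(=O)[nH]c2nc(SCC(=O)c3ccc(Cl)cc3)[nH]c2c1=O` gives 6300 nM. Compound 2 `Cn1c(=O)[nH]c2nc(SCC(=O)c3ccc(Br)cc3)[nH]c2c1=O` differs from compound 1 by bromo in place of chloro on an aromatic carbon, and in this assay compound 2 gives 11200 nM; the exchange produced a 1.8-fold higher number from compound 1 to compound 2 (0.25 log units; within the scatter). Compound 3 `Cn1c(=O)[nH]c2nc(SC/C(=N/O)c3ccc(Cl)cc3)[nH]c2c1=O` gives 1400 nM in this assay; how its core differs from the core of compound 1 is not broken down here. Compound 4 `Cn1c(=O)[nH]c2nc(SC/C(=N/O)c3ccc(Br)cc3)[nH]c2c1=O` has not been measured. It differs from compound 3 by bromo in place of chloro on an aromatic carbon, the same change that separates compound 1 from compound 2, at the same place. For compound 4 the expected step is a 1.6-fold higher number from compound 3 to compound 4 (0.20 log units; within the scatter), because the earlier exchange gave a 1.8-fold higher number from compound 1 to compound 2 (0.25 log units; within the scatter) and stayed within the usual scatter. Compound 4 is therefore estimated at 2200 nM in this assay. The expected range for compound 4 runs from 900 nM to 5000 nM.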

Compound 4, half-maximal inhibitory concentration: 1700 nM
Compound 4: middle estimate off by 1.3-fold (0.11 log units), on the high side, within the range that was stated.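

In this assay, putting bromo in place of chloro on the core of compound 3 gave a 1.2-fold higher number from compound 3 to compound 4 (0.08 log units; within the scatter). Set beside the earlier exchange, the result on this second core cannot be told apart from the first, so within this small set the change carried over from one core to the other: the same change on two cores in this assay, a 1.8-fold higher number (0.25 log units; within the scatter) from compound 1 to compound 2 and a 1.2-fold higher number (0.08 log units; within the scatter) from compound 3 to compound 4, 1.5-fold (0.17 log units) apart, within the scatter of two such steps. This supports only a narrow statement, that going from 4-chlorophenyl to 4-bromophenyl moved the number by no more than the usual scatter in these two pairs; it does not show that the two halogens are interchangeable on other cores or in other assays, and it says nothing about why the numbers stay close.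

The compounds shown carry only chloro or bromo at this place on the ring, which leaves open what fluoro, a methoxy group, an amine or a carboxylic acid would do there. Also open, from the compounds shown here alone, is whether the exchange stays this small when a longer chain replaces the sulfur-linked side chain.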